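The source may report more compounds than this note shows. Statements on the series, on what has been measured and on what is new or still open speak of the compounds shown alone.

Going by the values given here, compound 1 `CCOC(=O)C1=Cc2ccccc2OC1(OCc1cn(CC(=O)Nc2cccc(Cl)c2)nn1)C(F)(F)F` gives 10100 nM in a functional assay on DU-145 cells (Homo sapiens) for inhibition, read by MTT assay, with a stated time of 24 h (on this read-out lower numbers stand for stronger inhibition and higher numbers for weaker inhibition), the only numerical value available in this set. Compound 2 `CCOC(=O)C1=Cc2ccccc2OC1(OCc1cc(-c2ccc(C)cc2)no1)C(F)(F)F` yields only a limit in this assay, > 150000 nM, and no number. Compound 3 `CCOC(=O)C1=Cc2ccccc2OC1(OCc1cn(CC(=O)NC2CCCCC2)nn1)C(F)(F)F` differs from compound 1 by cyclohexyl in place of 3-chlorophenyl on an amide-type nitrogen. No measured step of this kind exists among the compounds shown, so the direction rests on expectation alone. Compound 3 is expected to be somewhat weaker, a step of a 2.2-fold higher number from compound 1 to compound 3 (0.34 log units; beyond the scatter) in this assay that may exceed the scatter. The estimate for compound 3 is 22000 nM, within a range from 7000 nM to 80000 nM.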

Compound 3, half-maximal inhibitory concentration: 10200 nM
Beside the measured number, compound 3's estimate is 2.2-fold (0.33 log units) above it, and the stated range covers the measured number.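

In this assay, the amide-type nitrogen accepts a non-aromatic ring as readily as an aromatic one: cyclohexyl in place of 3-chlorophenyl gives a 1.0-fold higher number from compound 1 to compound 3 (0.00 log units; within the scatter). For this pair, neither the chlorine nor the aromatic character of the ring shifts the read-out. Nothing shown explains why the number holds. From the compounds shown here alone, it remains open whether any ring is needed on this nitrogen, since a methyl group or a short alkyl chain could behave differently. A ring carrying a carboxylic acid or an amine is equally untested by the compounds shown here.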